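Swapping a hexyloxy chain for a cyclohexyl ring

The source may hold more compounds than are shown below. What is called first, only, known or untested is meant among the compounds shown, and "the series" means these compounds.

In a functional assay on brain (Rattus norvegicus, strain Wistar) for inhibition (on this read-out higher numbers stand for weaker inhibition and lower numbers for stronger inhibition), compound 1 (`CCCCc1ccc(-c2c(C)[nH]c(=O)n2C2CCCCC2)cc1`) gives 27100 nM, compound 2 (`CCCCCc1ccc(-c2c(C)[nH]c(=O)n2C2CCCCC2)cc1`) gives 10600 nM, and compound 3 (`CCCCCCOc1ccc(-c2c(C)[nH]c(=O)n2C2CCCCC2)cc1`) gives 8500 nM. Compound 3 therefore shares the stronger end of this small set with compound 2, the two being level within the scatter: a 1.2-fold lower number from compound 2 to compound 3 (0.10 log units; within the scatter). It stands clearly apart from the weaker compound 1: a 3.2-fold lower number from compound 1 to compound 3 (0.50 log units; beyond the scatter).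

The next molecule, compound 4 (`Cc1[nH]c(=O)n(C2CCCCC2)c1-c1ccc(C2CCCCC2)cc1`), keeps the shared core but carries cyclohexyl in place of hexyloxy on an aromatic carbon.

The closest guides are the measured changes at this same carbon and along its chain. Methyl in place of hydrogen on the butyl chain gave a modest gain, a 2.6-fold lower number from compound 1 to compound 2 (0.41 log units; beyond the scatter), and the swap from butyl to hexyloxy gave a similar one, a 3.2-fold lower number from compound 1 to compound 3 (0.50 log units; beyond the scatter). Hexyloxy in place of pentyl made no difference beyond the scatter. None of these compounds carries a ring at this carbon, so the data offer no direct precedent and the uncertainty is wide. With that caution, the expected change is small, probably within the scatter: a 1.3-fold higher number from compound 3 to compound 4 (0.11 log units; within the scatter). For compound 4 the estimated value is 11000 nM, with an expected range from 4000 nM to 30000 nM.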

Compound 4, half-maximal inhibitory concentration: 28900 nM
Compound 4: the middle estimate sits 2.6-fold (0.42 log units) below what was measured; low and high end bracket the measured number.
By their numbers in this assay, from the lowest: compounds 3 and 2 (each within the scatter of the next); then compounds 1 and 4 (each within the scatter of the next).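

At this aromatic carbon, a ring does not behave like an open chain of similar size: in this assay, cyclohexyl in place of hexyloxy raises the number (a 3.4-fold higher number from compound 3 to compound 4 (0.53 log units; beyond the scatter)), and cyclohexyl in place of pentyl raises it too (a 2.7-fold higher number from compound 2 to compound 4 (0.44 log units; beyond the scatter)). Against the shorter butyl chain, the ring makes no difference beyond the scatter (a 1.1-fold higher number from compound 1 to compound 4 (0.03 log units; within the scatter)), so compound 4 stands level with compound 1 and shows none of the gain seen with the pentyl and hexyloxy chains. Pentyl has no oxygen to lose, so the rise in the step to compound 4 does not depend on removing the oxygen of hexyloxy, but nothing available explains why the ring gives a weaker result.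

From the compounds shown here alone, it remains open whether a smaller ring such as cyclopentyl, a flat phenyl ring or an oxygen-containing tetrahydropyranyl ring would give the same result as cyclohexyl at this carbon. Also open, going by these compounds, is whether a longer chain such as octyloxy, or a chain ending in an amine, would bring the number below that of compound 3.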